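A Chloropyridine Amide Follows an Enone Amide

This account rests on a few compounds, and the source may have more. Where it says the series, first, only, none or still open, it means among the compounds named here.

Compound 1 `C/C=C/C(=O)Nc1cccc(-c2nc3ccccc3s2)c1` gives 1640 10^-6 cm/s in an ADME assay for permeability, using PAMPA; on this read-out higher numbers stand for higher permeability and lower numbers for lower permeability.
Compound 2 `O=C(CCl)Nc1cccc(-c2nc3ccccc3s2)c1` gives 660 10^-6 cm/s in this assay.

Compound 1 stands highest of the two numbers. The move to compound 3 `O=C(Nc1cccc(-c2nc3ccccc3s2)c1)c1cccnc1Cl` is 2-chloropyridin-3-yl in place of prop-1-en-1-yl on a carbonyl carbon. Going by the values given here, only one measured step changes the same carbonyl carbon: a 2.5-fold lower number from compound 1 to compound 2 (0.40 log units; beyond the scatter). That step brought in a chloromethyl, whereas here a six-membered aromatic ring with one nitrogen enters, so the comparison is loose; still, a drop of similar size seems more likely than a rise. Compound 3 is therefore expected to give 900 10^-6 cm/s, within 400 10^-6 cm/s to 1800 10^-6 cm/s, which would mean a 1.8-fold lower number from compound 1 to compound 3 (0.26 log units; within the scatter).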

Compound 3, apparent permeability: 677 10^-6 cm/s
Compound 3: the middle estimate sits 1.3-fold (0.12 log units) above what was measured, and the stated range covers the measured number.
By their numbers in this assay, from the lowest: compounds 2 and 3 (each within the scatter of the next); then compound 1.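

On the carbonyl carbon, two very different groups give numbers that cannot be told apart in this assay: swapping chloromethyl for 2-chloropyridin-3-yl, with its six-membered aromatic ring, gives (a 1.0-fold higher number from compound 2 to compound 3 (0.01 log units; within the scatter)). Against prop-1-en-1-yl, the same ring group gives (a 2.4-fold lower number from compound 1 to compound 3 (0.38 log units; beyond the scatter)), so both replacements now sit beyond the scatter from compound 1, which holds the highest number of the three. Nothing measured here explains these numbers.

As far as these compounds go, how the ring's chlorine and its nitrogen each contribute remains open, as a plain phenyl ring would be needed to separate them from the ring itself. Also open, from the compounds shown here alone, is how an amine or a longer carbon chain on this carbonyl carbon would compare.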